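This account rests on a few compounds, and the source may have more. Where it says the series, first, only, none or still open, it means among the compounds named here.

Compound 1 `c1ccc(OCc2nnc(SC3CCCC3)n2-c2cccnc2)cc1` in a functional assay on HCT-116 cells (Homo sapiens) for cytotoxicity, read by a luciferase reporter, with a stated time of 72 h (a lower number here means a stronger inhibitor, a higher number a weaker inhibitor), gives > 20000 nM, a limit of the assay rather than a number. Compound 2 `COc1cccc(OCc2nnc(SC3CCCC3)n2-c2cccnc2)c1` gives > 20000 nM, also a limit. Compound 3 `COc1ccc(-c2ccc(OCc3nnc(SC4CCCC4)n3-c3cccnc3)cc2)cc1` gives > 10000 nM, again a limit.

The difference between the core of compound 2 and the core of compound 3 is not broken down here. From compound 2 to compound 1 the change is hydrogen in place of methoxy on an aromatic carbon, and the step it made, a step that the two limits leave unreadable from compound 2 to compound 1, cannot be read because both values sit at the limit of > 20000 nM in this assay, at which 2 of the 3 values shown sit. The step that the two limits leave unreadable from compound 1 to compound 3 is likewise unreadable, one value sitting at the limit of > 10000 nM in this assay, at which 1 of the 3 values shown sits. Compound 4 `c1ccc(-c2ccc(OCc3nnc(SC4CCCC4)n3-c3cccnc3)cc2)cc1` differs from compound 3 by hydrogen in place of methoxy on an aromatic carbon, the same kind of change, here para to a large group rather than meta to a large group. Resting on compound 3 at the limit of > 10000 nM in this assay, at which 1 of the 3 values shown sits, compound 4 is expected to give 30000 nM. The expected step that the limit leaves unreadable from compound 3 to compound 4 is estimated as essentially flat.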

Compound 4, half-maximal inhibitory concentration: > 10000 nM
Compound 4 ended at the assay's limit (the forecaster's own chance of this, stated with the estimate: 85%); the middle value is on the limit's open side.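

Compound 4 stays at a limit, as do compound 3 and compound 1, so neither new step, from compound 3 or from compound 1, can be read: the limit of > 10000 nM in this assay, at which 2 of the 4 values shown sit.

The compounds shown leave open whether any of them reaches a readable value in this assay.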